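Three Inactive Relatives and a Bulkier Amide Partner

The source may hold more compounds than are shown below. What is called first, only, known or untested is meant among the compounds shown, and "the series" means these compounds.

Of the compounds shown here, three built on a shared core have been tested in an assay for inhibition of tyrosine-protein kinase receptor TYRO3 (Homo sapiens), read by 33P incorporation, in the presence of a further agent that is not named here (on this read-out higher numbers stand for weaker inhibition and lower numbers for stronger inhibition), and none of them gave a number. Compound 1 `CNc1ncc2c(-c3ccc(N4CCNCC4)nc3)nn(CC3OCCO3)c2n1` reaches only the limit of the assay, > 10000 nM. Compound 2 `CNc1ncc2c(-c3ccc(OC)cc3)nn(CC3OCCO3)c2n1` likewise stops at the limit, > 10000 nM. Compound 3 `CNc1ncc2c(-c3ccc(N4CCN(C)CC4)nc3)nn(Cc3cn(Cc4ccccc4)nn3)c2n1`, the starting point of this step, also sits at the limit in this assay, > 10000 nM. That is where compound 3 stands: at the limit, where every value shown sits (the limit of > 10000 nM in this assay, at which 3 of the 3 values shown sit), so that no ordering among the three can be read.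

Compound 4 `CNc1ncc2c(-c3ccc(N4CCN(C(=O)C(C)(C)C)CC4)nc3)nn(Cc3cn(Cc4ccccc4)nn3)c2n1` differs from compound 3 in one place: (tert-butyl)carbonyl in place of methyl on an amine nitrogen in a ring. Among the compounds with values here, no pair of measured compounds shows what such an exchange does in this assay. Within the data shown here, with all three values resting at the limit, there is no measured step to lean on. The expected step is a step that the limit leaves unreadable from compound 3 to compound 4, meaning none beyond the usual scatter in either direction. The estimate for compound 4 in this assay is therefore 20000 nM, between 5000 nM and 100000 nM, most likely reported again only as a limit.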

Compound 4, half-maximal inhibitory concentration: > 10000 nM
Compound 4 gave a limit, no number; the forecaster's own chance of this, stated with the estimate: 85%; the middle value does not contradict the limit.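

No step can be read from compound 3 to compound 4, since each gives only a limit in this assay and no number, as does the whole set: the limit of > 10000 nM in this assay, at which 4 of the 4 values shown sit.

The compounds shown leave open how strongly any of them inhibits, and whether (tert-butyl)carbonyl in place of methyl changes that at all.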